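A few compounds are considered here, and "the series" means these few. Any claim that something is new, unique, unknown or untested is made for them only; others in the source may bear on it.

Compound 1 `CC[C@]1(c2ccccc2)OC(=O)NC1=O`: 91 mg/kg
Compound 2 `CCC1(c2ccccc2)OC(=O)N(C)C1=O`: 124 mg/kg
Compound 3 `CC[C@@]1(c2ccccc2)OC(=O)NC1=O`: 141 mg/kg

These values come from a functional assay on the whole organism with Mus musculus as the target, in the maximal electroshock model, with a stated time of 0.5 h; a lower number here means that less compound is needed, a higher number that more compound is needed for the effect. In this assay, compound 3 at 141 mg/kg lies within the usual scatter of both other compounds, so the numbers do not separate it from either one.

Compound 4 `CCC1(c2ccccc2)OC(=O)NC1=O` is the next to consider. The structural change from compound 3 is the two compounds have the same atoms and bonds; at least one stereo element is drawn with a configuration in one of them and without one in the other: 1 of 1 stereo elements differ; a stereocentre at a saturated ring carbon is drawn S in compound 3 and without a configuration in compound 4. The stereocentre at a saturated ring carbon is therefore the only thing that differs.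

Within the data shown here, one measured step bears on this: a 1.5-fold higher number from compound 1 to compound 3 (0.19 log units; within the scatter). What sets that pair apart is the fact that compounds 1 and 3 differ only in the configuration as drawn. Configuration at this stereocentre thus moved the number by no more than the scatter, so no step beyond the scatter is expected here, in either direction.

The expected step is a 1.3-fold lower number from compound 3 to compound 4 (0.10 log units; within the scatter). Compound 4 is estimated at 112 mg/kg, with an expected range of 75 mg/kg to 165 mg/kg.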

Compound 4, dose for half-maximal effect: 86 mg/kg
Estimate against measurement, compound 4: 1.3-fold (0.11 log units) above; measured number inside the range.
By their numbers in this assay, from the lowest: compounds 4, 1, 2 and 3 (each within the scatter of the next).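

In this assay, drawing the stereocentre without a configuration gives a 1.6-fold lower number from compound 3 to compound 4 (0.21 log units; within the scatter) and a 1.1-fold lower number from compound 1 to compound 4 (0.02 log units; within the scatter), so compound 4 separates from neither drawn form. Among these compounds, the only difference in each of these pairs is how that saturated ring carbon is drawn, and with the earlier pair of drawn forms this means that no comparison at this stereocentre has yet moved the number beyond the scatter: the fact that one of compounds 3 and 4 is drawn with a defined configuration and the other without, at the place where they differ The first step at the nitrogen, hydrogen in place of methyl on an amide-type nitrogen in a ring, gives a 1.4-fold lower number from compound 2 to compound 4 (0.16 log units; within the scatter), so the numbers do not separate these two compounds either.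

The compounds shown leave open how the number responds to a benzyl group on that nitrogen. They also leave open the effect of a longer chain in place of the ethyl group, or of a chlorine on the phenyl group.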